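The source may report more compounds than this note shows. Statements on the series, on what has been measured and on what is new or still open speak of the compounds shown alone.

Compounds measured in a functional assay on HCT-116 cells (Homo sapiens) for cytotoxicity, read by MTT assay, with a stated time of 48 h; on this read-out lower numbers stand for stronger inhibition of growth and higher numbers for weaker inhibition of growth:
Compound 1 `Clc1cc2ncn(C3CCCC3)c2cc1Cl`: 37000 nM
Compound 2 `CC(C)c1nc2cc(Cl)c(Cl)cc2n1C1CCCC1`: 9000 nM
Compound 3 `C[S+]([O-])c1nc2cc(Cl)c(Cl)cc2n1C1CCCC1`: 500 nM

Among these three, compound 3 has the lowest number, 500 nM, and its gaps to both of the others lie beyond the scatter. Compound 4 `CS(=O)(=O)c1nc2cc(Cl)c(Cl)cc2n1C1CCCC1` has not yet been measured. It differs from compound 3 in one group, on an aromatic carbon of a five-membered aromatic ring with 2 nitrogen: a group of 4 heavy atoms (1 carbon, 2 oxygen, 1 sulfur; no ring) in place of a group of 3 heavy atoms (1 carbon, 1 oxygen, 1 sulfur; no ring), on an aromatic carbon. Methylsulfonyl is the entering group.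

Among the measured compounds shown here, three measured steps concern this same carbon. The step of a 4.1-fold lower number from compound 1 to compound 2 (0.61 log units; beyond the scatter) was modest, while a 74-fold lower number from compound 1 to compound 3 (1.87 log units; beyond the scatter) and an 18-fold lower number from compound 2 to compound 3 (1.26 log units; beyond the scatter) were both large. The number in this assay has therefore moved considerably with the group placed here, and the largest gains came with the group of compound 3. None of these steps introduces methylsulfonyl, so the data give no direct measure of this change.

Both groups contain sulfur and oxygen, so a result near compound 3 at 500 nM is the expectation, with no step beyond the scatter in either direction, though with wide uncertainty. The expected change is a 1.3-fold lower number from compound 3 to compound 4 (0.10 log units; within the scatter). For compound 4 the estimated value is 400 nM, within an expected range of 120 nM to 1800 nM.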

Compound 4, concentration for 50% growth inhibition: 600 nM
Beside the measured number, compound 4's estimate is 1.5-fold (0.18 log units) below it, within the range that was stated.
By their numbers in this assay, from the lowest: compounds 3 and 4 (each within the scatter of the next); then compound 2; then compound 1.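

In this assay the change from the group of compound 3 to methylsulfonyl on this aromatic carbon gave a 1.2-fold higher number from compound 3 to compound 4 (0.08 log units; within the scatter) and so leaves the two groups indistinguishable in this read-out, even though methylsulfonyl carries one more oxygen and one more hydrogen-bond acceptor. Compound 4 also keeps the large advantage seen with compound 3, with a 15-fold lower number from compound 2 to compound 4 (1.18 log units; beyond the scatter) and a 62-fold lower number from compound 1 to compound 4 (1.79 log units; beyond the scatter), so that among the four compounds shown, both groups containing sulfur and oxygen have lower numbers than isopropyl or hydrogen, and no compound goes against this. Nothing among the data presented accounts for this pattern or for the lack of a clear separation between these two groups.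

Going by these compounds, it remains open whether sulfur is needed at this carbon at all, or whether an amine, a carboxylic acid, a sulfonamide or a longer chain ending in methylsulfonyl would give numbers in the same region. On these data alone, all four compounds also bear the same cyclopentyl group, so it is equally open whether the pattern would hold with a different group on that ring atom.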